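The source may report more compounds than this note shows. Statements on the series, on what has been measured and on what is new or still open speak of the compounds shown alone.

In an ADME assay on blood (Homo sapiens) for protein binding, read by LC-MS, using equilibrium dialysis (on this read-out lower numbers stand for a smaller free fraction and higher numbers for a larger free fraction), compound 1 (`CNC(=O)c1cc(C(=O)N[C@H]2[C@@H]3C[C@H](O)C[C@@H]32)n([C@@H](C)c2cccc(Cl)c2)n1`) has "not determined" (no result reported) as its entry, so it offers no number from which to start. Among the compounds with values here, the only number available in this small set belongs to compound 2 (`CNC(=O)c1cc(C(=O)N[C@H]2CC[C@H](O)CC2)n([C@@H](C)c2ccccc2)n1`), which gives 0.44 on this read-out.

Compound 3 (`CNC(=O)c1cc(C(=O)N[C@H]2[C@@H]3C[C@@H](O)C[C@@H]32)n([C@@H](C)c2cccc(Cl)c2)n1`) is reached from compound 1 through a single change of drawn configuration (the two compounds have the same atoms and bonds and differ only in configuration as drawn: 1 of 5 stereo elements differ; a stereocentre at a saturated ring carbon is drawn S in compound 1 and R in compound 3), and no atom or bond is added or removed. Within the data shown here, no measured pair shows what a change of this kind does to the unbound fraction. The step expected in this assay on going from compound 1 to compound 3 is therefore none beyond the usual scatter, with neither direction favoured.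

Without a value for compound 1, the estimate has to lean on compound 2 at 0.44 as a rough scale only, and the range is kept wide to reflect this. For compound 3 the estimated unbound fraction is 0.35, with an expected range from 0.15 to 0.6 in repeated measurements.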

Compound 3, unbound fraction in the Homo sapiens assay: 0.2
For compound 3 the middle estimate is 1.8-fold (0.24 log units) above the measured one; measured number inside the range.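

Within the data shown here, no step between compound 1 and compound 3 can be read from these results. In a physicochemical assay for solubility, measured as kinetic solubility (a lower number here means a less soluble compound, a higher number a more soluble compound), compound 1 gives >= 168 ug/mL, which is a limit of the assay and not a number. In the physicochemical assay compound 3 gives 175 ug/mL. Left open is whether the stereocentre at the saturated ring carbon, drawn S or R, affects either unbound fraction or solubility.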